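This account rests on a few compounds, and the source may have more. Where it says the series, first, only, none or still open, it means among the compounds named here.

Measured so far:
compound 1 `COc1cccc(C(=O)Nc2nc(-c3ccccn3)cs2)c1` gives 2800 nM in an ADME assay on Vero cells (Chlorocebus sabaeus) for cytotoxicity, read by MTT assay, with a stated time of 72 h; on this read-out higher numbers stand for an effect only at larger amounts of compound and lower numbers for an effect already at smaller amounts
compound 2 `COc1ccc(C(=O)Nc2nc(-c3ccccn3)cs2)cc1` gives 9200 nM in this assay
compound 3 `CC(=O)c1cccc(C(=O)Nc2nc(-c3ccccn3)cs2)c1` gives 1500 nM in this assay

Compound 2 has the highest number of the three in this assay; compound 1 and compound 3 both lie lower, and each of those gaps is beyond the usual scatter. Compound 1 and compound 2 are built from the same atoms joined differently; the difference between the two cores is not broken down here.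

One change occurs twice in the set. From compound 1 to compound 3 the change is acetyl in place of methoxy on an aromatic carbon and it gave a 1.9-fold lower number from compound 1 to compound 3 (0.27 log units; within the scatter). Compound 4 `CC(=O)c1ccc(C(=O)Nc2nc(-c3ccccn3)cs2)cc1` is still to be measured in this assay and differs from compound 2 by acetyl in place of methoxy on an aromatic carbon. The two changes are of the same kind but not the same: in compound 3 the acetyl sits meta to a large group, in compound 4 it sits para to a large group. With a single earlier instance, and that one within the scatter, there is little to carry across beyond a small movement in the same direction.

For compound 4 in this assay the step from compound 2 is estimated as a 1.8-fold lower number from compound 2 to compound 4 (0.26 log units; within the scatter), resting on the earlier step of a 1.9-fold lower number from compound 1 to compound 3 (0.27 log units; within the scatter). Compound 4 is therefore expected to give about 5000 nM, with the likely range running from 2500 nM to 10000 nM.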

Compound 4, half-maximal effective concentration: 10500 nM
For compound 4 the middle estimate is 2.1-fold (0.32 log units) below the measured one; measured number above the stated range.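

In this assay, acetyl in place of methoxy on an aromatic carbon, para to a large group, gave a 1.1-fold higher number from compound 2 to compound 4 (0.06 log units; within the scatter). Set beside the earlier instance of the same change, the two cores cannot be told apart in their response: the same change on two cores in this assay, a 1.9-fold lower number (0.27 log units; within the scatter) from compound 1 to compound 3 and a 1.1-fold higher number (0.06 log units; within the scatter) from compound 2 to compound 4, 2.1-fold (0.33 log units) apart, within the scatter of two such steps. This supports carrying the change from one core to the other as a step too small to read in this assay, but it does not show that the change has no effect on either core, or that the two cores respond identically, and two steps within the scatter establish no direction for the series.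

The compounds shown leave open whether a group of another kind in the same place, such as an amine or a carboxylic acid, would move the number beyond the scatter on either core. Also open, on these data alone, is whether a longer chain in place of acetyl, or a change elsewhere on the shared core, would shift the number in this assay, since only the methoxy and acetyl pair has been compared here.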